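A few compounds are considered here, and "the series" means these few. Any claim that something is new, unique, unknown or untested is made for them only; others in the source may bear on it.

Values measured in a functional assay on A549 cells (Homo sapiens) for cytotoxicity, read by MTT assay, with a stated time of 72 h; on this read-out higher numbers stand for weaker inhibition and lower numbers for stronger inhibition:

- Compound 1 `CCOC(=O)c1c(C)oc2ncnc(Nc3cccc(C)c3)c12`: > 1000000 nM (a limit of the assay, not a number)
- Compound 2 `CCOC(=O)c1c(C)oc2ncnc(Nc3ccc(OCc4cccc(Cl)c4)cc3)c12`: 513000 nM
- Compound 3 `Cc1oc2ncnc(Nc3cccc(Cl)c3)c2c1C(=O)NC(C)C`: > 1000000 nM (a limit of the assay, not a number)

Within the data shown here, compound 2 gives the only actual number, 513000 nM. The other reference point is the limit of > 1000000 nM in this assay, at which 2 of the 3 values shown sit.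

Compound 4 `CCOC(=O)c1c(C)oc2ncnc(Nc3ccc(OCc4ccc(C)cc4)cc3)c12` carries 4-methylphenyl in place of 3-chlorophenyl on a saturated chain carbon bound to an oxygen on an aromatic ring.

Among the measured compounds shown here, no measured pair shows what a swap of this kind does, so no change beyond the usual scatter is expected. The estimated step, a 1.1-fold higher number from compound 2 to compound 4 (0.03 log units; within the scatter), therefore stays small. For compound 4 the expected value is 550000 nM, with an estimated range of 200000 nM to 1000000 nM.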

Compound 4, half-maximal inhibitory concentration: > 1000000 nM
Compound 4 gave a limit, no number; the forecaster's own chance of this, stated with the estimate: 35%; middle value at least 1.8-fold (0.25 log units) away from the limit.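

Among these compounds, replacing 3-chlorophenyl with 4-methylphenyl on a saturated chain carbon bound to an oxygen on an aromatic ring gives the first step at this position, an at least 1.9-fold higher number from compound 2 to compound 4 (0.28 log units; that floor lies within the scatter), so it does not establish a real loss. In this assay compound 4 gives > 1000000 nM, a limit of the assay and not a number. Only a floor for the step can be read, because compound 4 joins the other compounds at that limit: the limit of > 1000000 nM in this assay, at which 3 of the 4 values shown sit.

Still open, going by these compounds, is which part of the swap matters, the chlorine or its place on the ring. Also open, on these data alone, is whether an amine or a carboxylic acid here would give a clearly lower number than compound 2.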